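This account rests on a few compounds, and the source may have more. Where it says the series, first, only, none or still open, it means among the compounds named here.

Compound 1, `COc1ccc(OC)c(/C=C/c2nnc(Nc3ccc(Cl)cc3)o2)c1`: > 100000 nM in a functional assay on SK-MEL-5 cells (Homo sapiens) for antiproliferative activity, read by sulforhodamine B assay, with a stated time of 48 h; a lower number here means a stronger inhibitor of growth, a higher number a weaker inhibitor of growth
Compound 2, `COc1ccc(OC)c(/C=C/C(=O)N/N=C/c2ccc(Cl)cc2)c1`: "not determined" (no result reported) in this assay

The value of compound 1 in this assay is a limit of the assay, not a number, and it sits at the limit of > 100000 nM in this assay, at which 1 of the 2 values shown sits. For compound 2 no result was reported in this assay, so compound 2 stands nowhere on the numbers shown; the only value beside it belongs to another compound and is itself a limit.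

Compound 3, `COc1ccc(OC)c(/C=C/C(=O)N/N=C/c2ccccc2)c1`, is not yet measured. It differs from compound 2 by hydrogen in place of chloro on an aromatic carbon. Among the measured compounds shown here, no measured step exists for this change, and with compound 1 reaching only a limit and compound 2 giving no number, the data offer no direction; a step within the scatter of this assay is the expectation. Compound 3 is estimated at 30000 nM in this assay, with a range from 3000 nM to 100000 nM, and a real chance that only a limit is reported.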

Compound 3, concentration for total growth inhibition: 14600 nM
Beside the measured number, compound 3's estimate is 2.1-fold (0.31 log units) above it; the measured number falls inside the stated range.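

Among the compounds shown here, compound 2 carries no number in this assay, so no step to compound 3, which gives 14600 nM, can be read. The compounds shown leave open whether going from 4-chlorophenyl to phenyl changes growth inhibition at all, and in which direction.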